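The compounds below may be only part of what the source reports. "The series", "measured", "known", "first", "only" and "open" are said of these compounds alone.

Measured compounds:
compound 1 `O=C(NCc1ccc(CNS(=O)(=O)c2cccc(Cl)c2)cc1)c1ccc(F)cc1` — in an assay on MDA-MB-231 cells for binding affinity to C-X-C chemokine receptor type 4 (Homo sapiens), read by fluorescence and microscopy, with stated times of 10 min and 30 min (on this read-out higher numbers stand for an effect only at larger amounts of compound and lower numbers for an effect already at smaller amounts), compound 1 gives 1 nM
compound 2 `O=C(NCc1ccc(CNS(=O)(=O)c2ccc(Cl)cc2)cc1)c1ccc(F)cc1` — compound 2 gives 100 nM

In this assay compound 2 has the highest of the two numbers; its nearest neighbour is compound 1, separated by a 100-fold higher number from compound 1 to compound 2 (2.00 log units; beyond the scatter). Compound 3 `O=C(NCc1ccc(CNS(=O)(=O)c2ccccc2F)cc1)c1ccc(F)cc1` is not yet measured; it differs from compound 2 by 2-fluorophenyl in place of 4-chlorophenyl on a sulfonyl sulfur. Going by the values given here, the one measured step that bears on it is a 100-fold higher number from compound 1 to compound 2 (2.00 log units; beyond the scatter), which shows that exchanging 3-chlorophenyl for 4-chlorophenyl on the sulfonyl sulfur changes the number greatly. Among the compounds with values here, no measured step covers 2-fluorophenyl, so the expectation is uncertain: a step of a 5.0-fold lower number from compound 2 to compound 3 (0.70 log units; beyond the scatter) towards a lower number is expected. For compound 3 the estimate is 20 nM, range 2 nM to 300 nM.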

Compound 3, effective concentration (reported as EC, without a stated level of effect): 10 nM
Compound 3: middle estimate off by 2.0-fold (0.30 log units), on the high side; low and high end bracket the measured number.
By their numbers in this assay, from the lowest: compound 1; then compound 3; then compound 2.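

With 2-fluorophenyl on the sulfonyl sulfur, the step of a 10-fold lower number from compound 2 to compound 3 (1.00 log units; beyond the scatter) and the step of a 10-fold higher number from compound 1 to compound 3 (1.00 log units; beyond the scatter) put this group between the two chlorophenyl groups, so the outcome at this position is not limited to the two chlorophenyl extremes. The halogen and its place on the ring change together in both steps, so their contributions cannot be separated. Nothing available explains these differences. Still open, on these data alone, are 2-chlorophenyl and 3-fluorophenyl, which would separate halogen from place, and whether an amine or carboxylic acid on this ring would keep the number low.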